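From Fluoro to Methoxy on Compound 1

The source may hold more compounds than are shown below. What is called first, only, known or untested is meant among the compounds shown, and "the series" means these compounds.

For the measured compounds named here, in an ADME assay on CHO cells (Cricetulus griseus) for cytotoxicity, read by LDH release (on this read-out higher numbers stand for weaker inhibition and lower numbers for stronger inhibition), compound 1 `CC(Oc1ccc(Cl)cc1Cl)C(=O)NCc1cccc(F)c1` gives 27000 nM, the only exact number among the measured compounds. Compound 2 `CC(Oc1ccc(Cl)cc1Cl)C(=O)NCc1ccccc1Cl` reads > 100000 nM, which is a limit of the assay. Compound 3 `Cc1ccccc1CNC(=O)C(C)Oc1ccc(Cl)cc1Cl` reads > 100000 nM, which is also a limit. Compound 4 `COc1cccc(CNC(=O)C(C)Oc2ccc(Cl)cc2Cl)c1` has methoxy in place of fluoro on an aromatic carbon. Two measured steps replace the 3-fluorophenyl group of compound 1: an at least 3.7-fold higher number from compound 1 to compound 2 (0.56 log units; beyond the scatter) and an at least 3.7-fold higher number from compound 1 to compound 3 (0.56 log units; beyond the scatter). Neither is the same change, so they offer only indirect guidance, and both give a lower bound on size. On that basis, a modest move towards a higher number is expected, with the estimated step being a 1.9-fold higher number from compound 1 to compound 4 (0.27 log units; within the scatter). For compound 4 the estimate is 50000 nM, with an expected range of 18000 nM to 100000 nM.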

Compound 4, half-maximal inhibitory concentration: > 100000 nM
Compound 4: a limit, no number; the forecaster's own chance of this, stated with the estimate: 35%; middle value at least 2.0-fold (0.30 log units) from the limit.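

In this assay, the change stays on one aromatic carbon, meta to a large group, and gives an at least 3.7-fold higher number from compound 1 to compound 4 (0.56 log units; beyond the scatter). The earlier steps shown here changed the group and its place together, whereas this one shows that methoxy in place of fluoro at the same place is enough to reach the limit. The size remains only a lower bound, because compound 4 reads a limit, not a number: the limit of > 100000 nM in this assay, at which 3 of the 4 values shown sit.

Going by these compounds, how far compound 2, compound 3 and compound 4 lie past that limit stays open. So does whether an amine or a carboxylic acid at this place would give an exact number.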